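The source may report more compounds than this note shows. Statements on the series, on what has been measured and on what is new or still open speak of the compounds shown alone.

Measured compounds:
compound 1, `Cc1ccc(C2=NN(c3ccc(S(C)(=O)=O)cc3)C(=O)CC2)cc1`: 46.7%
compound 2, `CS(=O)(=O)c1ccc(N2N=C(c3ccccc3)CCC2=O)cc1`: 26.6%

In a functional assay on the whole organism (strain Wistar) for inhibition, with Rattus norvegicus as the target, read by paw edema, with stated times of 30 min and 3 h, at a dose of 0.05 mmol/kg by the oral route (on this read-out lower numbers stand for less inhibition and higher numbers for more inhibition at the one dose given (going by the name of the read-out)), compound 2 stands lowest of the two numbers, with compound 1 nearest. Compound 3, `Cc1cc(O)ccc1C1=NN(c2ccc(S(C)(=O)=O)cc2)C(=O)CC1`, is not yet measured; it differs from compound 2 as follows: 4-hydroxy-2-methylphenyl in place of phenyl on a carbon with a double bond to nitrogen. Among the compounds with values here, the one measured step bearing on this, a number 20.1 percentage points lower from compound 1 to compound 2 (beyond the scatter), shows that hydrogen in place of methyl on an aromatic carbon lowered the read-out, so restoring a methyl should raise it. Within the data shown here, no measured step covers the hydroxy, so that part is uncertain. Compound 3 is therefore expected to give 40%, in the range 20% to 60%. The expected step is a number 13.4 percentage points higher from compound 2 to compound 3 (beyond the scatter).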

Compound 3, a percentage reported as inhibition, in the whole organism at one dose (the size of the read-out at that dose, not a potency): 33.3%
Beside the measured number, compound 3's estimate is 6.7 percentage points above it; the measured number falls inside the stated range.
By their numbers in this assay, from the lowest: compounds 2 and 3 (each within the scatter of the next); then compound 1.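

In this assay, putting 4-hydroxy-2-methylphenyl in place of phenyl on this carbon with a double bond to nitrogen gives a number 6.7 percentage points higher from compound 2 to compound 3 (within the scatter), so the larger group cannot be told apart from phenyl here. Putting it in place of 4-methylphenyl gives a number 13.4 percentage points lower from compound 1 to compound 3 (beyond the scatter), so having a methyl somewhere on this ring does not by itself carry over the higher number of compound 1. Nothing available explains these results. The compounds shown leave open whether the hydroxy or the methyl sets the number of compound 3, and how a methoxy or chloro group on this ring would read.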